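Methoxy in place of hydroxy on the phenylpiperazine arm

The source may hold more compounds than are shown below. What is called first, only, known or untested is meant among the compounds shown, and "the series" means these compounds.

Measured so far:
compound 1 `COc1cc2ncnc(N3CCC(CN4CCN(c5ccccc5)CC4)C3)c2cc1OC` 251 nM
compound 2 `COc1cc2ncnc(N3CCC(CN4CCN(c5ccccc5O)CC4)C3)c2cc1OC` 661 nM

In an assay on membranes from CHO-K1 cells for displacement of a labelled ligand from 5-hydroxytryptamine receptor 7 (Homo sapiens), read by scintillation counting (a higher number here means a weaker inhibitor, a lower number a stronger inhibitor), compound 2 gives 661 nM, the highest of the two numbers; its nearest neighbour is compound 1, and a 2.6-fold higher number from compound 1 to compound 2 (0.42 log units; beyond the scatter). Compound 3 `COc1cc2ncnc(N3CCC(CN4CCN(c5ccccc5OC)CC4)C3)c2cc1OC` differs from compound 2 by methyl in place of hydrogen on an oxygen on an aromatic ring. Among the compounds with values here, no measured step covers this exact change; the only step at hand is the one from compound 1 to compound 2, which shows that the group at this position moves the number modestly. Compound 3 is therefore expected to land near or a little under compound 2, as a 1.9-fold lower number from compound 2 to compound 3 (0.28 log units; within the scatter), an estimate of 350 nM within 120 nM to 1000 nM.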

Compound 3, inhibition constant: 56.2 nM
For compound 3 the middle estimate is 6.2-fold (0.79 log units) above the measured one, and the stated range ends above it.
By their numbers in this assay, from the lowest: compound 3; then compound 1; then compound 2.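

Putting a methyl on the oxygen turns the weakest of the three compounds into the strongest (a 12-fold lower number from compound 2 to compound 3 (1.07 log units; beyond the scatter)), so one added carbon has a large effect here. Methoxy also outperforms plain hydrogen (a 4.5-fold lower number from compound 1 to compound 3 (0.65 log units; beyond the scatter)), although hydroxy gave a weaker compound than hydrogen, so the two oxygen groups move the number in opposite directions. Nothing available explains this reversal. On these data alone, it remains open whether ethoxy, with a longer chain on the oxygen, would match methoxy, and whether an amine or chlorine in its place would do as well.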